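A Second Methoxy Group on the Amide Aryl Ring

A few compounds are considered here, and "the series" means these few. Any claim that something is new, unique, unknown or untested is made for them only; others in the source may bear on it.

Compound 1, `COc1ccc(NC(=O)c2cccc(/C=C3\CC(=O)N(c4ccccc4)C3=O)c2)cc1`: in an ADME assay on HCT-116 cells (Homo sapiens) for cytotoxicity, read by MTT assay, with a stated time of 72 h (a lower number here means a stronger inhibitor, a higher number a weaker inhibitor), compound 1 gives > 100000 nM, which is a limit of the assay rather than a number.
Compound 2, `COc1ccc(NC(=O)c2cccc(/C=C3\CC(=O)N(c4ccc(C)cc4)C3=O)c2)cc1`: in this assay compound 2 gives > 100000 nM, likewise a limit.

Going by the values given here, compound 1 therefore stands only at a limit, and the one other value shown is a limit as well, so its place on a scale of real numbers is not known. The step that the two limits leave unreadable from compound 1 to compound 2 is left unreadable by those two limits. Among the compounds with values here, the only evidence is the limit of > 100000 nM in this assay, at which 2 of the 2 values shown sit. Compound 3, `COc1ccc(OC)c(NC(=O)c2cccc(/C=C3\CC(=O)N(c4ccccc4)C3=O)c2)c1`, carries 2,5-dimethoxyphenyl in place of 4-methoxyphenyl on an amide-type nitrogen. The measured step gives no readable size and touches a different part of the shared core, so no step beyond the scatter can be expected in this assay in either direction; the expectation is simply that compound 3 also comes to rest at the limit. Compound 3 is therefore estimated at 150000 nM, with a range from 50000 nM to 500000 nM. The expected step is a step that the limit leaves unreadable from compound 1 to compound 3.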

Compound 3, half-maximal inhibitory concentration: > 100000 nM
Compound 3 was reported as a limit; the forecaster's own chance of this, stated with the estimate: 85%; the middle value lies beyond the limit too.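

Compound 1 and compound 3 both sit at a limit in this assay, so the step between them cannot be read: the limit of > 100000 nM in this assay, at which 3 of the 3 values shown sit. Left open is whether compound 1, compound 2 and compound 3 differ at all in this assay, and whether any change to the shared core would give a real number there.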